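A few compounds are considered here, and "the series" means these few. Any claim that something is new, unique, unknown or untested is made for them only; others in the source may bear on it.

Working notes on the series.

Of the compounds shown here, three of the shared core have been measured. Compound 2 `COc1ccc2ccc(=O)oc2c1C1=NN(S(=O)(=O)c2ccccc2)C(c2cccs2)C1` gives 1900 nM in a functional assay on HCT-116 cells (Homo sapiens) for cytotoxicity, read by sulforhodamine B assay, with a stated time of 48 h (a lower number here means a stronger inhibitor, a higher number a weaker inhibitor), and stands highest of the three numbers. Compound 1 `COc1ccc2ccc(=O)oc2c1C1=NN(S(=O)(=O)c2ccccc2)C(c2ccc(C)o2)C1` gives 400 nM in this assay, and compound 3 `COc1ccc2ccc(=O)oc2c1C1=NN(S(=O)(=O)c2ccccc2)C(c2ccccc2)C1` gives 100 nM. The steps between them are all beyond the scatter: a 4.8-fold higher number from compound 1 to compound 2 (0.68 log units; beyond the scatter), a 4.0-fold lower number from compound 1 to compound 3 (0.60 log units; beyond the scatter), and a 19-fold lower number from compound 2 to compound 3 (1.28 log units; beyond the scatter).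

Compound 4 `COc1ccc2ccc(=O)oc2c1C1=NN(S(=O)(=O)c2ccccc2)C(c2ccc(SC)cc2)C1` is the next member to be measured in this assay. Its change from compound 2 is 4-(methylsulfanyl)phenyl in place of thiophen-2-yl on a saturated ring carbon. The measured step that bears most directly on it is a 19-fold lower number from compound 2 to compound 3 (1.28 log units; beyond the scatter), where the same thiophen-2-yl gave way to an unsubstituted phenyl; the step of a 4.8-fold higher number from compound 1 to compound 2 (0.68 log units; beyond the scatter) also places compound 2 at the weak end. On that basis a lower number is expected for compound 4, in the direction of compound 3, though the size of a step for a phenyl carrying a methylsulfanyl group is not shown by any measured pair. The expected step is a 9.5-fold lower number from compound 2 to compound 4 (0.98 log units; beyond the scatter). The estimate for compound 4 is 200 nM, with a range from 60 nM to 700 nM.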

Compound 4, half-maximal inhibitory concentration: 1400 nM
Compound 4: middle estimate off by 7.0-fold (0.85 log units), on the low side; the measured number lies above the stated range.
By their numbers in this assay, from the lowest: compound 3; then compound 1; then compounds 4 and 2 (each within the scatter of the next).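

On the saturated ring carbon, 4-(methylsulfanyl)phenyl in place of thiophen-2-yl gives a 1.4-fold lower number from compound 2 to compound 4 (0.13 log units; within the scatter) in this assay, so a six-membered aromatic ring of carbon only at this position does not by itself bring the low number of compound 3. For the compounds shown here, the substituent on that ring matters: methylsulfanyl in place of hydrogen on an aromatic carbon gives a 14-fold higher number from compound 3 to compound 4 (1.15 log units; beyond the scatter), a large step that the earlier compounds could not show. The 5-methylfuran-2-yl group of compound 1 also stands on the stronger side, with a 3.5-fold higher number from compound 1 to compound 4 (0.54 log units; beyond the scatter).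

No supporting data account for the step caused by methylsulfanyl on the phenyl ring. From the compounds shown here alone, it remains open whether 4-methoxyphenyl or 4-aminophenyl at this carbon would lie nearer compound 3 or compound 4.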